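This account rests on a few compounds, and the source may have more. Where it says the series, first, only, none or still open, it means among the compounds named here.

Going by the values given here, compound 1 `Cc1ccc(CCCN(CC[C@H](N)C(=O)O)C[C@H]2O[C@@H](n3cnc4c(N)ncnc43)[C@H](O)[C@@H]2O)cc1C(N)=O` stands lowest of the three numbers so far in an assay on cells for inhibition of Nicotinamide N-methyltransferase (Homo sapiens), read by fluorescence and coupled enzyme assay, with a stated time of 10 min, in the presence of a further agent that is not named here; a lower number here means a stronger inhibitor, a higher number a weaker inhibitor: compound 1 gives 51 nM. Compound 2 `NC(=O)c1cccc(CCCN(CCC[C@H](N)C(=O)O)C[C@H]2O[C@@H](n3cnc4c(N)ncnc43)[C@H](O)[C@@H]2O)c1`, which carries its carboxamide-bearing ring without the methyl group and on a longer chain, gives 3000 nM in this assay, and compound 3 `Nc1ncnc2c1ncn2[C@@H]1O[C@H](CN(CCCc2cccc3ccccc23)CC[C@H](N)C(=O)O)[C@@H](O)[C@H]1O`, in which the carboxamide-bearing ring has been exchanged for a naphthalen-1-yl group, gives 11800 nM.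

Compound 4 `Nc1ncnc2c1ncn2[C@@H]1O[C@H](CN(CCCc2ccc3ccccc3c2)CC[C@H](N)C(=O)O)[C@@H](O)[C@H]1O` differs from compound 1 in one place: a group of 10 heavy atoms (10 carbon; 2 six-membered aromatic rings of carbon only) in place of a group of 10 heavy atoms (8 carbon, 1 nitrogen, 1 oxygen; one six-membered aromatic ring of carbon only), on a saturated chain carbon, three bonds along the chain from an amine nitrogen. Among the compounds with values here, the step that bears directly on this change is the one from compound 1 to compound 3, where a naphthalene ring took the place of the same carboxamide-bearing ring and the number rose sharply: a 230-fold higher number from compound 1 to compound 3 (2.36 log units; beyond the scatter). Within the data shown here, compound 4 carries the naphthalene attached at a different position, and no measured pair shows what that shift alone does. On the evidence of compound 3, a large rise in this assay is expected for compound 4 as well, in the direction of weaker inhibition, of the order of a 120-fold higher number from compound 1 to compound 4 (2.07 log units; beyond the scatter). The estimate for compound 4 in this assay is therefore 6000 nM, with a range from 1200 nM to 30000 nM.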

Compound 4, inhibition constant: 4000 nM
Compound 4: the middle estimate sits 1.5-fold (0.18 log units) above what was measured; the range from low to high includes it.
By their numbers in this assay, from the lowest: compound 1; then compounds 2 and 4 (each within the scatter of the next); then compound 3.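

In this assay, putting naphthalen-2-yl in place of the carboxamide-bearing ring, on a saturated chain carbon, three bonds along the chain from an amine nitrogen, brings a large rise, with a 78-fold higher number from compound 1 to compound 4 (1.89 log units; beyond the scatter), so the loss seen with naphthalen-1-yl is not confined to that one form of the naphthalene. The form of the naphthalene also counts, though far less than the loss of the carboxamide-bearing ring, with a 3.0-fold lower number from compound 3 to compound 4 (0.47 log units; beyond the scatter), and this is the first pair shown in which only that attachment changes. Nothing at hand explains either step.

The compounds shown leave open which part of the ring of compound 1 matters, for no pair separates the carboxamide from the methyl group, and compound 2 differs from compound 1 in more than one place. They also do not show whether a plain phenyl ring, a carboxylic acid or a nitrile in place of the carboxamide, or a shorter chain leading to the ring, would keep the number close to that of compound 1.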